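A Chloro Added to the Benzyl Arm of Compound 3

The compounds below may be only part of what the source reports. "The series", "measured", "known", "first", "only" and "open" are said of these compounds alone.

Compound 1 `COc1ccc(C2N=C(SCc3ccccc3)NC(C)=C2C(=O)Nc2ccc(F)cc2)cc1OC` gives 8.8% in a functional assay on the whole organism (artery, strain albino) with Rattus norvegicus as the target, with a stated time of 120 min, at a dose of 10 mg/kg by the oral route; on this read-out higher numbers stand for more inhibition at the one dose given (going by the name of the read-out) and lower numbers for less inhibition.
Compound 2 `COc1ccc(C2N=C(SCc3cccc(Cl)c3)NC(C)=C2C(=O)Nc2ccc(F)cc2)cc1OC` gives 10.8% in this assay.
Compound 3 `CC1=C(C(=O)Nc2ccc(F)cc2)C(c2ccc([N+](=O)[O-])cc2)N=C(SCc2ccccc2)N1` gives 18% in this assay.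

All three compounds share one core and differ only in a single group each. Compound 3 gives the largest number of the three, yet its gaps to the other two are small: a number 9.2 percentage points higher from compound 1 to compound 3 (within the scatter), and the values of compound 2 and compound 3 lie within the usual scatter of each other. So no compound can be set apart from the others on these numbers.

Compound 4 `CC1=C(C(=O)Nc2ccc(F)cc2)C(c2ccc([N+](=O)[O-])cc2)N=C(SCc2ccc(Cl)cc2)N1` is compound 3 with one change: chloro in place of hydrogen on an aromatic carbon. Among the measured compounds shown here, one measured step bears on this, the pair of compound 1 and compound 2, where a chloro likewise replaced a hydrogen on an aromatic carbon of the benzyl arm: a number 2 percentage points higher from compound 1 to compound 2 (within the scatter). That step did not move the read-out beyond the scatter, and nothing else in the data separates the two positions. The same change on compound 3 is therefore expected to give no step beyond the scatter in this assay, which means an expected a number 2 percentage points higher from compound 3 to compound 4 (within the scatter). The estimate for compound 4 is 20%, with a range from 8% to 32%.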

Compound 4, a percentage reported as inhibition, in the whole organism at one dose (the size of the read-out at that dose, not a potency): 16%
Estimate against measurement, compound 4: 4 percentage points above, within the range that was stated.
By their numbers in this assay, from the lowest: compounds 1, 2, 4 and 3 (each within the scatter of the next).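

Going from benzyl to 4-chlorobenzyl gives a number 2 percentage points lower from compound 3 to compound 4 (within the scatter) in this assay, so a chlorine para to a large group on this aromatic ring produces no change that can be told from the scatter. The direction of this small step carries no meaning, and the same holds for the step from hydrogen to chloro on the benzyl arm of the other core. Until now, this change had been seen only once, on the core with the 3,4-dimethoxyphenyl group and at a different ring carbon, whereas it has now been seen on two cores and at two places on the arm, and the two results agree: the same change on two cores in this assay, a number 2 percentage points higher (within the scatter) from compound 1 to compound 2 and a number 2 percentage points lower (within the scatter) from compound 3 to compound 4, 4 percentage points apart, within the scatter of two such steps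

The compounds shown carry only hydrogen or chloro on this ring, so it remains open whether an amine, a carboxylic acid or a longer chain at the same place would move the read-out beyond the scatter. The fluorophenyl group on the amide and the methyl group on the shared core are also the same in all four compounds, which leaves the effect of changing either one unknown.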